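The source may report more compounds than this note shows. Statements on the series, on what has been measured and on what is new or still open speak of the compounds shown alone.

Of the compounds shown here, three of a shared core have been tested in an ADME assay on Vero cells (Chlorocebus sabaeus) for cytotoxicity, read by MTT assay, with a stated time of 72 h; a lower number here means that less compound is tolerated, a higher number that more compound is tolerated. Compound 1 `CCOC(=O)c1c(-c2ccc(OC)cc2)oc2ccc(OCCCCCN3C(=O)C(=O)c4cc(F)ccc43)cc12` gives 128000 nM in this assay. Compound 2 `CCOC(=O)c1c(-c2ccc(OC)cc2)oc2ccc(OCCCCCCN3C(=O)C(=O)c4cc(F)ccc43)cc12` gives 128000 nM in this assay, level with compound 1 at the digits shown; together the two give the lowest numbers of the three. For the measured compounds named here, compound 3 `CCOC(=O)c1c(-c2ccc(F)cc2)oc2ccc(OCCCCCCN3C(=O)C(=O)c4cc(F)ccc43)cc12` gives 512000 nM in this assay, and the step of a 4.0-fold higher number from compound 2 to compound 3 (0.60 log units; beyond the scatter) is the only one measured between neighbours.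

Compound 4 `CCOC(=O)c1c(-c2ccc(OC)cc2)oc2ccc(OCCCCCCN3C(=O)C(=O)c4ccccc43)cc12` differs from compound 2 by hydrogen in place of fluoro on an aromatic carbon. Going by the values given here, no measured step touches that position: the single step from compound 2 to compound 3 concerns the fluoro that replaces the methoxy on the other aryl ring, and so it does not speak to removing the fluoro here. The expectation therefore rests on compound 2 alone, with a step of no change at the digits printed from compound 2 to compound 4 (within the scatter) expected to stay within the scatter. Compound 4 is estimated at 128000 nM in this assay, with a range from 40000 nM to 400000 nM.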

Compound 4, half-maximal cytotoxic concentration: 256000 nM
The estimate for compound 4 lay 2.0-fold (0.30 log units) below the measured number; measured number inside the range.
By their numbers in this assay, from the lowest: compounds 1, 2, 4 and 3 (each within the scatter of the next, the first and the last beyond it).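

In this assay, for the compounds shown here, the first reading at this position, hydrogen in place of fluoro on an aromatic carbon, gives a 2.0-fold higher number from compound 2 to compound 4 (0.30 log units; within the scatter), so compound 4 without the fluoro cannot be told apart from compound 2 here. The wider swap of the whole group on the saturated chain carbon gives a 2.0-fold higher number from compound 1 to compound 4 (0.30 log units; within the scatter), and it also stays inside the usual scatter, whereas the fluoro in place of methoxy on the other aryl ring remains the only single change shown to go beyond it. Nothing available explains why this position makes so little difference. As far as these compounds go, whether a larger group at this position, such as chloro, methoxy or trifluoromethyl, would also leave the number in place stays open. So does whether removing this fluoro reads the same alongside the fluoro-bearing aryl ring of compound 3.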